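A few compounds are considered here, and "the series" means these few. Any claim that something is new, unique, unknown or untested is made for them only; others in the source may bear on it.

Compound 2 `CCN(Cc1ccccn1)c1ccc(C(=O)N2CCc3ccc(OS(N)(=O)=O)cc3C2)cc1` stands highest of the three compounds measured in an assay on HEK293 cells for inhibition of Steryl-sulfatase (Homo sapiens), tested at 0.1 uM (a lower number here means a weaker effect, a higher number a stronger effect of the compound at the concentration tested), where compound 2 gives 42.5%. Its nearest neighbour is compound 3 `CN(C)CCCN(Cc1ccccc1)c1ccc(C(=O)N2CCc3ccc(OS(N)(=O)=O)cc3C2)cc1`, which in this assay gives 16.2%, a number beyond the scatter below it, and furthest lies compound 1 `NS(=O)(=O)Oc1ccc2c(c1)CN(C(=O)c1ccc(N3CCCCC3)cc1)CC2`, which gives 11.5% in this assay.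

Compound 4 `CC(C)CCN(CCC(C)C)c1ccc(C(=O)N2CCc3ccc(OS(N)(=O)=O)cc3C2)cc1` has not yet been measured. It differs from compound 2 in one place: diisopentylamino in place of ethyl((pyridin-2-yl)methyl)amino on an aromatic carbon.

Among the compounds with values here, only one measured step touches the same position: a number 31 percentage points higher from compound 1 to compound 2 (beyond the scatter), where ethyl((pyridin-2-yl)methyl)amino replaced piperidin-1-yl. That step is now undone in the sense that the ethyl((pyridin-2-yl)methyl)amino group leaves again, and the group that enters, diisopentylamino, has no ring, as does neither the group of compound 1 nor that of compound 3, both of which gave low numbers. Compound 4 is therefore expected to fall back toward those two, with a step of a number 24.5 percentage points lower from compound 2 to compound 4 (beyond the scatter) downward beyond the scatter. The estimate for compound 4 in this assay is 18%, within a range from 5% to 38%.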

Compound 4, a percentage reported as inhibition, at one concentration (the size of the read-out at that concentration, not a potency): 47%
The estimate for compound 4 lay 29 percentage points below the measured number; measured number outside the range, above it.
By their numbers in this assay, from the lowest: compounds 1 and 3 (each within the scatter of the next); then compounds 2 and 4 (each within the scatter of the next).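

In this assay the ring of the leaving group turns out not to be needed at this place, on an aromatic carbon para to a large group: with diisopentylamino, which has no ring, the read-out shows a number 4.5 percentage points higher from compound 2 to compound 4 (within the scatter) and so stays level. A group without a ring can therefore match ethyl((pyridin-2-yl)methyl)amino here, and the same open-chain group gives a number 35.5 percentage points higher from compound 1 to compound 4 (beyond the scatter) against the ring of piperidin-1-yl. Nothing at hand accounts for this difference between the two amines.

As far as these compounds go, whether a shorter open-chain amine such as diethylamino, or a ring with a second hetero atom such as morpholin-4-yl, would stay level with compound 2 and compound 4 or drop to the level of compound 1 remains open. A read-out at one concentration also leaves the potencies of compound 2 and compound 4 unknown.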